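The source may hold more compounds than are shown below. What is called first, only, known or untested is meant among the compounds shown, and "the series" means these compounds.

Measured compounds and their values:
- compound 1 `O=C(C[C@]1(O)CC[C@H](Cc2ccc(F)cc2)CC1)Nc1ccc2[nH]c(=O)oc2c1` gives 42.3 mL/min/kg
- compound 2 `O=C(C[C@]1(O)CC[C@@H](Cc2ccc(Cl)cc2)CC1)Nc1ccc2[nH]c(=O)oc2c1` gives "not determined" (no result reported)

The read-out here is an ADME assay on the whole organism (strain Sprague-Dawley) for pharmacokinetics, with Rattus norvegicus as the target, using cassette dosing (on this read-out lower numbers stand for slow clearance and higher numbers for fast clearance), which tells how quickly the body of a rat removes a compound from the blood. For the measured compounds named here, compound 1 is the only compound with a number in this assay, where compound 1 gives 42.3 mL/min/kg. Going by the values given here, compound 2 stands nowhere on these numbers: for compound 2 the assay reports "not determined" (no result reported), so it offers no anchor of its own, and the only value in hand belongs to compound 1.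

Compound 3 `O=C(C[C@]1(O)CC[C@@H](Cc2ccc(OC(F)(F)F)cc2)CC1)Nc1ccc2[nH]c(=O)oc2c1` differs from compound 2 by one change (trifluoromethoxy in place of chloro on an aromatic carbon), a trifluoromethoxy group in place of a chloro group on the aromatic ring. Among the compounds with values here, no measured pair shows what such a change does in this assay, so the step from compound 2 to compound 3 cannot be sized from data; the expectation is that it stays within the usual scatter, with no clear direction. With compound 2 unmeasured, the estimate for compound 3 leans on compound 1 at 42.3 mL/min/kg. Compound 3 is therefore expected to give about 45 mL/min/kg, within 20 mL/min/kg to 95 mL/min/kg.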

Compound 3, clearance: 21 mL/min/kg
Compound 3: the middle estimate sits 2.1-fold (0.33 log units) above what was measured, and the stated range covers the measured number.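

For the compounds shown here, compound 2 has no number in this assay to set beside compound 3, so no step between these two compounds can be read. The compounds shown leave open what replacing chloro with trifluoromethoxy does to clearance in rats. No further measurement shown here helps to explain the result for compound 3.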